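The compounds below may be only part of what the source reports. "The series", "measured", "known", "first", "only" and "open" are said of these compounds alone.

Measured compounds in an ADME assay on WI-38 cells (Homo sapiens) for cytotoxicity, read by MTT assay, with a stated time of 72 h; on this read-out lower numbers stand for stronger inhibition and higher numbers for weaker inhibition:
- compound 1, `CN(C)CCn1cnnc1-c1cc(Oc2ccc(NC(=O)Nc3ccc(F)c(F)c3)cc2F)ccn1`: > 50000 nM
- compound 2, `CCN(CC)CCn1cnnc1-c1cc(Oc2ccc(NC(=O)Nc3ccc(Cl)c(C(F)(F)F)c3)cc2F)ccn1`: 6730 nM
- compound 3, `CN(C)CCCn1cnnc1-c1cc(Oc2ccc(NC(=O)Nc3ccc(Cl)c(C(F)(F)F)c3)cc2F)ccn1`: 7910 nM

Compound 1 gives only a limit in this assay, (the limit of > 50000 nM in this assay, at which 1 of the 3 values shown sits), and no number. Compound 2 gives 6730 nM and compound 3 gives 7910 nM. Among the two numbers, compound 3 stands highest, though the step of a 1.2-fold higher number from compound 2 to compound 3 (0.07 log units; within the scatter), a change in the amine-bearing side chain, lies within the scatter.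

Compound 4, `CN(C)CCCn1cnnc1-c1cc(Oc2ccc(NC(=O)Nc3ccc(F)c(F)c3)cc2F)ccn1`, has not yet been measured. It differs from compound 3 in one place, (3,4-difluorophenyl in place of 4-chloro-3-(trifluoromethyl)phenyl on an amide-type nitrogen). Among the compounds with values here, the only measured step concerns the side chain and so does not bear on this change. What does bear on it is compound 1, which carries the same 3,4-difluorophenyl group as compound 4 and differs from it only in the side chain, the part of the molecule where the measured step was within the scatter. Since compound 1 gives only a limit while compound 2 and compound 3, both with the 4-chloro-3-(trifluoromethyl)phenyl group, give numbers, the change is expected to raise the number, a 5.1-fold higher number from compound 3 to compound 4 (0.70 log units; beyond the scatter), with a fair chance that only a limit is reported. Compound 4 is thus estimated at 40000 nM, within a range of 12000 nM to 120000 nM.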

Compound 4, half-maximal inhibitory concentration: 15300 nM
Compound 4: middle estimate off by 2.6-fold (0.42 log units), on the high side, within the range that was stated.
By their numbers in this assay, from the lowest: compounds 2, 3 and 4 (each within the scatter of the next, the first and the last beyond it). At a limit, above all of these: compound 1.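

In this assay, putting 3,4-difluorophenyl in place of 4-chloro-3-(trifluoromethyl)phenyl on the amide-type nitrogen, with the side chain unchanged, gives a 1.9-fold higher number from compound 3 to compound 4 (0.29 log units; within the scatter), so this exchange on its own does not separate the two compounds. Within the data shown here, with 3,4-difluorophenyl held fixed, the side chain does separate them, and the change from dimethylamino to (dimethylamino)methyl on the saturated chain carbon gives an at least 3.2-fold lower number from compound 1 to compound 4 (0.51 log units; beyond the scatter), which is the first single change here that clearly moves the read-out. The 3,4-difluorophenyl group alone therefore does not bring a result at the limit, since compound 4 carries it and gives a number, while compound 1 remains a limit and not a number: the limit of > 50000 nM in this assay, at which 1 of the 4 values shown sits.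

Going by these compounds, the true size of the side chain step stays open, as only its lower bound can be read from a limit, and a single pair of compounds cannot show whether it would hold with 4-chloro-3-(trifluoromethyl)phenyl on the amide-type nitrogen. Also open, on these data alone, is how a longer chain or a ring amine such as morpholine would read at the end of the side chain, or how an unsubstituted phenyl would read on the amide-type nitrogen.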